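The source may report more compounds than this note shows. Statements on the series, on what has been measured and on what is new or still open speak of the compounds shown alone.

Compound 1, `CC(C)N(Cc1cccc(OCCCCCC(=O)O)c1)C(=O)c1ccc(-c2cccc(N(C)C)c2)cc1`: in an ADME assay on HepG2 cells (Homo sapiens) for cytotoxicity, read by CellTiter-Glo and resazurin assay, with a stated time of 72 h (a higher number here means that more compound is needed for the effect, a lower number that less compound is needed), compound 1 gives only a limit, > 26000 nM.
Compound 2, `CC(C)N(Cc1cccc(OCCCCCC(=O)O)c1)C(=O)c1ccc(-c2cccc3ccccc23)cc1`: in this assay compound 2 gives only a limit, > 26000 nM.
Compound 3, `CC(C)N(Cc1cccc(OCCCCCC(=O)O)c1)C(=O)c1ccc(-c2ccco2)cc1`: in this assay compound 3 gives only a limit, > 26000 nM.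

Compound 2 stands at the limit of this assay, as do the other two measured compounds; all three values sit at the limit of > 26000 nM in this assay, at which 3 of the 3 values shown sit. The steps among them are accordingly unreadable: a step that the two limits leave unreadable from compound 1 to compound 2, a step that the two limits leave unreadable from compound 1 to compound 3 and a step that the two limits leave unreadable from compound 2 to compound 3. The unmeasured compound 4, `COc1cccc(-c2ccc(C(=O)N(Cc3cccc(OCCCCCC(=O)O)c3)C(C)C)cc2)c1`, differs from compound 2 in one place: 3-methoxyphenyl in place of naphthalen-1-yl on an aromatic carbon. All three measured steps bear on this change, each exchanging the group on the same aromatic carbon, yet none has a readable size. No direction beyond the scatter can be read from them; the most that can be said is that each group tried at that position leaves the compound at the limit. Compound 4 is expected to stay there as well, and the step from compound 2 is estimated as a step that the limit leaves unreadable from compound 2 to compound 4. For compound 4 the estimate in this assay is 40000 nM, with a range from 18000 nM to 150000 nM.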

Compound 4, half-maximal effective concentration: > 26000 nM
Compound 4: no number, only a limit; the forecaster's own chance of this, stated with the estimate: 85%; the middle value lies beyond the limit too.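

Compound 4 gives only a limit in this assay, > 26000 nM. Its steps from compound 1, compound 2 and compound 3 cannot be read, since all four compounds sit at one limit: the limit of > 26000 nM in this assay, at which 4 of the 4 values shown sit.

The compounds shown leave open whether any group on that aromatic carbon gives a readable value, and how far apart these four compounds lie.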